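Moving the Fluorine on the Benzyl Amide of Compound 2

A few compounds are considered here, and "the series" means these few. Any claim that something is new, unique, unknown or untested is made for them only; others in the source may bear on it.

In a functional assay on HCT-116 cells (Homo sapiens) for antiproliferative activity, read by MTT assay, with a stated time of 72 h (a lower number here means a stronger inhibitor, a higher number a weaker inhibitor), compound 1 `COc1cccc(Sc2sc(C(C)=O)nc2[N+](=O)[O-])c1` gives 17300 nM and compound 3 `CC(=O)c1nc([N+](=O)[O-])c(Sc2c(Cl)cccc2Cl)s1` gives 19300 nM. Compound 2 `O=C(NCc1cccc(F)c1)c1nc([N+](=O)[O-])c(Sc2c(Cl)cncc2Cl)s1` has the lowest number of the three, at 6360 nM, and lies beyond the scatter from both others. Compound 4 `O=C(NCc1ccc(F)cc1)c1nc([N+](=O)[O-])c(Sc2c(Cl)cncc2Cl)s1` carries 4-fluorophenyl in place of 3-fluorophenyl on a saturated chain carbon bound to an amide-type nitrogen. Among the compounds with values here, no measured pair here shows a change of this kind, so the expectation starts from compound 2 at 6360 nM. No step beyond the scatter is expected in this assay, in either direction. The expected change is small, a 1.0-fold higher number from compound 2 to compound 4 (0.01 log units; within the scatter). For compound 4 the estimated value is 6500 nM, with an expected range of 3000 nM to 14000 nM.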

Compound 4, half-maximal inhibitory concentration: 11200 nM
Beside the measured number, compound 4's estimate is 1.7-fold (0.24 log units) below it, and the stated range covers the measured number.
By their numbers in this assay, from the lowest: compounds 2, 4, 1 and 3 (each within the scatter of the next, the first and the last beyond it).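

In this assay, moving the fluorine gives a 1.8-fold higher number from compound 2 to compound 4 (0.25 log units; within the scatter), the first step read at this position. On a saturated chain carbon bound to an amide-type nitrogen, 3-fluorophenyl and 4-fluorophenyl therefore cannot be told apart in this measurement, and the fluorine's place on the ring shows no effect beyond the scatter. Nothing available gives a cause for this result. Still open, as far as these compounds go, is how an unsubstituted phenyl, an amine, a carboxylic acid or a longer chain would read in place of the fluorophenyl. Also open, from the compounds shown here alone, is whether the same fluorine move would read alike on another core.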